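Two pyrazolyl chalcones and a dichlorophenyl analogue

The source may hold more compounds than are shown below. What is called first, only, known or untested is meant among the compounds shown, and "the series" means these compounds.

Measured so far:
compound 1, `COc1ccc(-c2cc(/C=C/C(=O)c3ccc(N)cc3)[nH]n2)cc1`, -74%
compound 2, `COc1cc(-c2cc(/C=C/C(=O)c3ccc(N)cc3)[nH]n2)cc(OC)c1OC`, -78%

In a functional assay on COLO 205 cells (Homo sapiens) for cytotoxicity, read by sulforhodamine B assay, with a stated time of 48 h, tested at 100 uM (on this read-out higher numbers stand for a weaker effect at the one concentration tested and lower numbers for a stronger effect), compound 1 gives -74%. In this assay compound 2 gives -78%. The two values sit within the usual scatter of each other, so on these numbers compound 2 is not separated from compound 1; both show a strong effect at the single concentration tested.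

Compound 3, `COc1cc(-c2cc(/C=C/C(=O)c3ccc(Cl)c(Cl)c3)[nH]n2)cc(OC)c1OC`, has not yet been measured in this assay. It differs from compound 2 in one place: 3,4-dichlorophenyl in place of 4-aminophenyl on a carbonyl carbon. For the measured compounds named here, no measured pair shows what such a change does here, and the two measured values give no step to lean on.

Without such a step the estimate rests on the shared core, which in compound 2 gives -78%. For compound 3 a step of a number 18 percentage points higher from compound 2 to compound 3 (beyond the scatter) toward a weaker effect is expected, with wide uncertainty. Compound 3 is estimated at -60%, in a range from -90% to -20%.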

Compound 3, a percentage reported as activity, at one concentration (the size of the read-out at that concentration, not a potency): -42%
For compound 3 the middle estimate is 18 percentage points below the measured one; the range from low to high includes it.
By their numbers in this assay, from the lowest: compounds 2 and 1 (each within the scatter of the next); then compound 3.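

Compounds 1 and 2 both carry the 4-aminophenyl group, so they said nothing about the group on the carbonyl carbon. For the compounds shown here, compound 3 shows that this place matters: in this assay, 3,4-dichlorophenyl in place of 4-aminophenyl gives a number 36 percentage points higher from compound 2 to compound 3 (beyond the scatter) and so a clearly weaker effect at the one concentration tested, which is the only size of change seen here for this group. Nothing available explains why the effect weakens with this change.

The change removes the amine and adds two chlorines at once, so the compounds shown leave open which of these matters, and an unsubstituted phenyl or a 4-chlorophenyl group on the same carbonyl carbon would begin to separate them. Also open, on these data alone, is whether the same exchange would have a similar effect on the core of compound 1.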